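Removing the tert-butyl group from a weak chalcone-like inhibitor

The source may report more compounds than this note shows. Statements on the series, on what has been measured and on what is new or still open speak of the compounds shown alone.

Compounds measured so far:
compound 1 `CC(C)(C)c1ccc(C(=O)/C=C/c2ccncc2)cc1`: 47000 nM
compound 2 `COc1cc(C(O)/C=C/c2ccncc2)cc(OC)c1OC`: > 100000 nM

In a functional assay with Rattus norvegicus as the target (on this read-out lower numbers stand for stronger inhibition and higher numbers for weaker inhibition), compound 1 gives 47000 nM. Compound 2 reaches only > 100000 nM, which is a limit of the assay rather than a number; this is the limit of > 100000 nM in this assay, at which 1 of the 2 values shown sits. For the measured compounds named here, compound 1 thus stands as the only compound with a number, and that number already marks it as a weak inhibitor.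

Compound 3 `O=C(/C=C/c1ccncc1)c1ccccc1` is the next compound, not yet measured. It differs from compound 1 in one place: hydrogen in place of tert-butyl on an aromatic carbon. Going by the values given here, no step between two measured compounds shows what this change does.

For this assay the change from compound 1 to compound 3 is expected to be a small step toward weaker inhibition, near the edge of the scatter, a 1.5-fold higher number from compound 1 to compound 3 (0.17 log units; within the scatter). Compound 3 is therefore estimated at 70000 nM, within a range from 25000 nM to 200000 nM.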

Compound 3, half-maximal inhibitory concentration: 49000 nM
For compound 3 the middle estimate is 1.4-fold (0.15 log units) above the measured one; low and high end bracket the measured number.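

In this assay the swap gives a 1.0-fold higher number from compound 1 to compound 3 (0.02 log units; within the scatter), so compound 1 and compound 3 cannot be told apart. On this aromatic carbon, then, the tert-butyl group is not needed for the weak inhibition seen with compound 1, and hydrogen serves just as well. Neither compound is a strong inhibitor, and the assay's ceiling is not far off: the limit of > 100000 nM in this assay, at which 1 of the 3 values shown sits.

Going by these compounds, whether an amine or a carboxylic acid on this same carbon would move the number beyond the scatter, in either direction, remains open. Also open, on these data alone, is whether the flat result holds only for these two groups, or whether this position has little influence on the read-out whichever group sits there.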